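Moving the alkoxy group on the hydrazone aryl ring

This account rests on a few compounds, and the source may have more. Where it says the series, first, only, none or still open, it means among the compounds named here.

Compounds measured so far in a functional assay on PC-3 cells (Homo sapiens) for antiproliferative activity, read by MTT assay, with a stated time of 72 h; on this read-out higher numbers stand for weaker inhibition and lower numbers for stronger inhibition:
Compound 1, `O=C(N/N=C/c1ccco1)c1cccc(S(=O)(=O)N2CCOCC2)c1`: compound 1 reaches only the limit > 100000 nM, a limit of the assay and not a number.
Compound 2, `O=C(N/N=C/c1ccccc1O)c1cccc(S(=O)(=O)N2CCOCC2)c1`: compound 2 gives 13800 nM.
Compound 3, `COc1ccc(/C=N/NC(=O)c2cccc(S(=O)(=O)N3CCOCC3)c2)c(O)c1`: compound 3 gives 5800 nM.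

Within the data shown here, compound 3 stands lowest of the two numbers known in this assay, with compound 2 nearest; the step of a 2.4-fold lower number from compound 2 to compound 3 (0.38 log units; beyond the scatter) lies beyond the scatter. Compound 1 is only known as a limit (the limit of > 100000 nM in this assay, at which 1 of the 3 values shown sits), and both an at least 7.2-fold lower number from compound 1 to compound 2 (0.86 log units; beyond the scatter) and an at least 17-fold lower number from compound 1 to compound 3 (1.23 log units; beyond the scatter) are accordingly at least of the size stated.

Compound 4, `CCOc1cccc(/C=N/NC(=O)c2cccc(S(=O)(=O)N3CCOCC3)c2)c1O`, has not yet been measured. It differs from compound 3 in one place: 3-ethoxy-2-hydroxyphenyl in place of 2-hydroxy-4-methoxyphenyl on a carbon with a double bond to nitrogen. The 2-hydroxy group stays, while the alkoxy group changes from methoxy to ethoxy and moves to a different ring position. The only step bearing on this is the modest gain a 2.4-fold lower number from compound 2 to compound 3 (0.38 log units; beyond the scatter) from adding a methoxy group; how a shifted, larger alkoxy group behaves is not shown by any pair. Compound 4 is therefore expected to sit near compound 3, with the step of a 1.2-fold higher number from compound 3 to compound 4 (0.08 log units; within the scatter) estimated to stay within the scatter. Compound 4 is estimated at 7000 nM in this assay, with a range from 2500 nM to 20000 nM.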

Compound 4, half-maximal inhibitory concentration: 15300 nM
The estimate for compound 4 lay 2.2-fold (0.34 log units) below the measured number; low and high end bracket the measured number.
By their numbers in this assay, from the lowest: compound 3; then compounds 2 and 4 (each within the scatter of the next). At a limit, above all of these: compound 1.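

In this assay, the 3-ethoxy-2-hydroxyphenyl group does not keep the gain seen with 2-hydroxy-4-methoxyphenyl, the change giving a 2.6-fold higher number from compound 3 to compound 4 (0.42 log units; beyond the scatter). Set against the 2-hydroxyphenyl group, ethoxy gives a 1.1-fold higher number from compound 2 to compound 4 (0.04 log units; within the scatter), so in this compound the added alkoxy group brings no change beyond the scatter, unlike the methoxy group of compound 3. Compound 1 remains a limit of the assay and not a number, so an at least 6.5-fold lower number from compound 1 to compound 4 (0.81 log units; beyond the scatter) is only a bound: the limit of > 100000 nM in this assay, at which 1 of the 4 values shown sits.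

The change from 2-hydroxy-4-methoxyphenyl to 3-ethoxy-2-hydroxyphenyl alters the alkoxy group and its ring position together, and the compounds shown do not separate the two. Also open, going by these compounds, is how a longer chain such as butoxy, or an amine such as dimethylamino, would behave on the 2-hydroxyphenyl ring.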